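Benzothienopyrimidinone ureas: aryl swap at the thiophene carbon

A few compounds are considered here, and "the series" means these few. Any claim that something is new, unique, unknown or untested is made for them only; others in the source may bear on it.

Going by the values given here, compound 3 `Cc1ccc(-c2cc3ncn([C@H]4CCN(C(=O)N(C)[C@H]5CCN(C)C5)C4)c(=O)c3s2)c(C)c1` gives in an assay on isolated protein for binding affinity to melanin-concentrating hormone receptor 1 (Homo sapiens) (on this read-out lower numbers stand for stronger inhibition and higher numbers for weaker inhibition), a value of 49 nM, the highest of the three numbers known so far. Among the compounds with values here, compound 1 `CN(C(=O)N1CC[C@H](n2cnc3cc(-c4ccc(Cl)cc4)sc3c2=O)C1)[C@H]1CCN(C2CCC(C)(C)CC2)C1` gives 2 nM and compound 2 `CN(C(=O)N1CC[C@H](n2cnc3cc(-c4ccc(Cl)cc4)sc3c2=O)C1)[C@H]1CCN(CC2CC2)C1` gives 3 nM in this assay; both differ from compound 3 at more than one place, so no single step to them is computed. Within the data shown here, the one computed step, a 1.5-fold higher number from compound 1 to compound 2 (0.18 log units; within the scatter), concerns the amine substituent and not the aryl group.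

Compound 4 `CN1CC[C@H](N(C)C(=O)N2CC[C@H](n3cnc4cc(-c5ccc6c(c5)OCCO6)sc4c3=O)C2)C1` differs from compound 3 by 2,3-dihydro-1,4-benzodioxin-6-yl in place of 2,4-dimethylphenyl on an aromatic carbon. Among the measured compounds shown here, no measured step touches this place, so nothing known bears directly on the change; the values of compound 1 and compound 2 only show that a different aryl group at the same place sits alongside a far lower number, while other parts change too.

With no directional evidence, compound 4 is expected to stay close to compound 3, the estimated step of a 1.6-fold lower number from compound 3 to compound 4 (0.21 log units; within the scatter) lying within the scatter. The estimate for compound 4 in this assay is 30 nM, with a range from 8 nM to 120 nM.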

Compound 4, inhibition constant: 143 nM
The estimate for compound 4 lay 4.8-fold (0.68 log units) below the measured number; measured number outside the range, above it.
By their numbers in this assay, from the lowest: compounds 1 and 2 (each within the scatter of the next); then compound 3; then compound 4.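

In this assay, the aryl place on the aromatic carbon next to the ring sulfur now has its first direct reading: 2,3-dihydro-1,4-benzodioxin-6-yl in place of 2,4-dimethylphenyl gives a 2.9-fold higher number from compound 3 to compound 4 (0.47 log units; beyond the scatter). The number at this place therefore responds to the aryl group, and the entering group, with its added six-membered non-aromatic ring with 2 hetero atoms, does not restore the low numbers of the other compounds shown. No measurement at hand accounts for the direction of this change.

The two compounds do not separate the effect of the added ring from that of its oxygens, which a phenyl carrying a single methoxy group on the same urea could address. From the compounds shown here alone, it also remains open whether plain phenyl would fall closer to compound 3 or to compound 4.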